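This account rests on a few compounds, and the source may have more. Where it says the series, first, only, none or still open, it means among the compounds named here.

Measured compounds:
Compound 1, `O=C(Nc1ccc(F)c(C(F)(F)F)c1)Nc1ccccn1`: 705 uL/min
Compound 2, `O=C(Nc1ccc(C(=O)O)cc1)Nc1ccc(F)c(C(F)(F)F)c1`: a limit, < 7 uL/min

Among the compounds with values here, in an ADME assay on microsomes from liver (Mus musculus) for metabolic stability, using NADPH, with a stated time of 60 min (on this read-out lower numbers stand for slow clearance and higher numbers for fast clearance), compound 1 gives 705 uL/min, the only plain number among the two results. For compound 2 the result in this assay is a limit of the assay rather than a number, (the limit of < 7 uL/min in this assay, at which 1 of the 2 values shown sits). Compound 3, `O=C(Nc1ccncc1)Nc1ccc(F)c(C(F)(F)F)c1`, is not yet measured. It differs from compound 1 in one place: pyridin-4-yl in place of pyridin-2-yl on an amide-type nitrogen. Within the data shown here, no measured pair shows this change, so the step from compound 1 to compound 3 in this assay is estimated at a 1.4-fold lower number from compound 1 to compound 3 (0.15 log units; within the scatter), expected to stay within the usual scatter. Compound 3 is therefore expected to give 500 uL/min, between 200 uL/min and 1400 uL/min.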

Compound 3, intrinsic clearance in a liver preparation (reported as CLH), per the amount of preparation that the assay uses in the Mus musculus assay: 37 uL/min
Compound 3: middle estimate off by 14-fold (1.13 log units), on the high side; the measured number lies below the stated range.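

In the Mus musculus assay, pyridin-4-yl in place of pyridin-2-yl on the amide-type nitrogen gives a 19-fold lower number from compound 1 to compound 3 (1.28 log units; beyond the scatter), the first sign that clearance at this position depends strongly on where the ring nitrogen sits, even with the same atoms. In a physicochemical assay for lipophilicity, read by HPLC, measured as octanol-water partition, at pH 7.2 (on this read-out higher numbers stand for higher lipophilicity and lower numbers for lower lipophilicity), compound 1 gives 3.7 and compound 3 gives 3.2, a gap beyond the scatter. This single pair cannot tell whether the two changes are linked.

From the compounds shown here alone, it remains open how pyridin-3-yl on the same nitrogen would behave, and whether an amine added to the pyridin-4-yl ring would keep clearance low.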